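The source may report more compounds than this note shows. Statements on the series, on what has been measured and on what is new or still open speak of the compounds shown alone.

Compound 1 `COc1ccc(C2=NN(C3=NC(=O)/C(=C4\C(=O)Nc5ccccc54)S3)C(c3ccc(OC)cc3)C2)cc1` gives 92200 nM in a functional assay on cells (Cancer cell lines, Homo sapiens) for cytotoxicity, read by sulforhodamine B assay, with a stated time of 48 h; a higher number here means a weaker inhibitor of growth, a lower number a stronger inhibitor of growth. Compound 2 `COc1ccc(C2=NN(C3=NC(=O)/C(=C4\C(=O)Nc5ccc(Br)cc54)S3)C(c3ccc(OC)cc3)C2)cc1` gives 240 nM in this assay, and the step from it, a 380-fold lower number from compound 1 to compound 2 (2.58 log units; beyond the scatter), follows the change (bromo in place of hydrogen on an aromatic carbon). Compound 3 `CN(C)c1ccc(C2CC(c3ccccc3)=NN2C2=NC(=O)/C(=C3\C(=O)Nc4ccccc43)S2)cc1` sits on a different core; how the core of compound 1 and the core of compound 3 differ is not broken down here. In this assay compound 3 gives 1220 nM. Compound 4 `CN(C)c1ccc(C2CC(c3ccccc3)=NN2C2=NC(=O)/C(=C3\C(=O)Nc4ccc(Br)cc43)S2)cc1` repeats the same change on the core of compound 3, (bromo in place of hydrogen on an aromatic carbon). Within the data shown here, the step from compound 3 to compound 4 is expected to be a 31-fold lower number from compound 3 to compound 4 (1.48 log units; beyond the scatter), a large drop, resting on the single earlier example a 380-fold lower number from compound 1 to compound 2 (2.58 log units; beyond the scatter) but tempered, since only one such example exists and it sits on another core. Compound 4 is therefore estimated at 40 nM, between 5 nM and 400 nM.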

Compound 4, concentration for 50% growth inhibition: 250 nM
Estimate against measurement, compound 4: 6.3-fold (0.80 log units) below; the measured number falls inside the stated range.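

Bromo in place of hydrogen on an aromatic carbon again lowers the number in this assay, with a 4.9-fold lower number from compound 3 to compound 4 (0.69 log units; beyond the scatter), so the direction of the step is the same on both cores. The size of the step does not carry from one core to the other: the same change on two cores in this assay, a 380-fold lower number (2.58 log units; beyond the scatter) from compound 1 to compound 2 and a 4.9-fold lower number (0.69 log units; beyond the scatter) from compound 3 to compound 4, 79-fold (1.90 log units) apart, beyond the scatter of two such steps

With a single pair on each core, the size of the step depends on the core in these compounds, but the pairs do not show which difference between the cores sets that size, nor what would happen on a further core.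

Open, as far as these compounds go, is whether chloro or methyl on the same aromatic carbon would follow bromo on either core. Also open, from the compounds shown here alone, is whether an amine or a carboxylic acid there would lower the number at all.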